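Moving the methyl from compound 3 to compound 4

The source may hold more compounds than are shown below. What is called first, only, known or untested is meant among the compounds shown, and "the series" means these compounds.

Of the compounds shown here, three sharing one core have been tested in a functional assay on SGC-7901 cells (Homo sapiens) for antiproliferative activity, read by MTT assay, with a stated time of 24 h; a higher number here means a weaker inhibitor, a lower number a stronger inhibitor. Compound 1 `Cc1cccc(-n2cc(-c3ccccc3NS(=O)(=O)c3c[nH]c(=O)[nH]c3=O)nn2)c1` gives 3510 nM. Compound 2 `O=c1[nH]cc(S(=O)(=O)Nc2ccc(-c3cn(-c4ccccc4)nn3)cc2)c(=O)[nH]1` gives 18800 nM. Compound 3 `Cc1ccccc1-n1cc(-c2ccc(NS(=O)(=O)c3c[nH]c(=O)[nH]c3=O)cc2)nn1` gives 13600 nM, which places compound 3 second highest of the three numbers: its nearest neighbour is compound 2, and the furthest is compound 1.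

Compound 4 `Cc1cccc(-n2cc(-c3ccc(NS(=O)(=O)c4c[nH]c(=O)[nH]c4=O)cc3)nn2)c1` differs from compound 3 in one place: 3-methylphenyl in place of 2-methylphenyl on an aromatic nitrogen. Within the data shown here, the only measured step that touches this part of the molecule is a 1.4-fold lower number from compound 2 to compound 3 (0.14 log units; within the scatter), a change too small to count. Among the measured compounds shown here, compound 1 also carries a 3-methylphenyl on the five-membered aromatic ring with 3 nitrogen, but its sulfonamide sits differently on the central ring, so no single step connects it to compound 3 or compound 4; its value and that of compound 3 merely show that the two differences together coincide with a lower number.

For the measured compounds named here, since the one relevant step was within the scatter, the move of the methyl from one carbon of the aryl ring to another is expected to give no step beyond the scatter, a 1.4-fold lower number from compound 3 to compound 4 (0.13 log units; within the scatter), with the range kept wide to allow for the direction suggested by compound 1. Compound 4 is therefore estimated at 10000 nM, between 4000 nM and 25000 nM.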

Compound 4, half-maximal inhibitory concentration: 17500 nM
The estimate for compound 4 lay 1.8-fold (0.24 log units) below the measured number; measured number inside the range.
By their numbers in this assay, from the lowest: compound 1; then compounds 3, 4 and 2 (each within the scatter of the next).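

In this assay, shifting the methyl on the aryl ring gives a 1.3-fold higher number from compound 3 to compound 4 (0.11 log units; within the scatter), so 3-methylphenyl and 2-methylphenyl on the aromatic nitrogen cannot be told apart here. Adding the methyl at this second place gives a 1.1-fold lower number from compound 2 to compound 4 (0.03 log units; within the scatter), which, together with a 1.4-fold lower number from compound 2 to compound 3 (0.14 log units; within the scatter), shows that neither methylphenyl compound separates from the plain phenyl of compound 2, whichever of these two places the methyl occupies. No measurement is available that could explain this flat result, or the values of these compounds more generally.

Methyl is the only group on this aryl ring among the compounds shown, so it remains open whether a methoxy group, an amine or a carboxylic acid there would move the number beyond the scatter. Going by these compounds, compound 1, which carries the same 3-methylphenyl but has its sulfonamide placed differently on the shared core, gives 3510 nM, whereas compound 4 gives 17500 nM, and it remains open whether the aryl group would matter more in the arrangement of compound 1.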